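Cyano for chloro in a serum binding series

This account rests on a few compounds, and the source may have more. Where it says the series, first, only, none or still open, it means among the compounds named here.

In an ADME assay on a cell-free system (serum, Homo sapiens) for protein binding (a lower number here means a smaller unbound share, a higher number a larger unbound share of the compound), compound 1 (`CC(=O)N1CCN(c2cccc(-c3ccc4c(N)ncnn34)c2)C(=O)C1(C)C`) has the entry "not determined" (no result reported) and so offers no number. Compound 2 (`CC(=O)N1CCN(c2cccc(-c3cc(C#N)c4c(N)ncnn34)c2)C(=O)C1(C)C`) is the only relative with a result (0.3). Like compound 1, compound 3 (`CC(=O)N1CCN(c2cc(-c3cc(Cl)c4c(N)ncnn34)ccc2Cl)C(=O)C1(C)C`) has no number either ("not determined" (no result reported)), so the step that follows starts from an unknown point.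

Compound 4 (`CC(=O)N1CCN(c2cc(-c3cc(Cl)c4c(N)ncnn34)ccc2C#N)C(=O)C1(C)C`) differs from compound 3 at a single place. The change sits ortho to a large group and para to a large group (cyano in place of chloro on an aromatic carbon).

Among the compounds with values here, no measured pair in this small set shows what such a swap does, so any step size is an expectation only. No step beyond the scatter is expected, and no direction can be called with confidence. Within the data shown here, the only anchor is compound 2 (0.3), which also carries a cyano group, though elsewhere on the molecule. Compound 4 is estimated at 0.25 with 0.1 to 0.5 as the expected range.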

Compound 4, unbound fraction: 0.17
Beside the measured number, compound 4's estimate is 1.5-fold (0.17 log units) above it; the measured number falls inside the stated range.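

Compound 4 gives 0.17 in this assay, but compound 3 offers no number to set beside it, so no step can be read between them. Going by these compounds, what cyano in place of chloro does to the unbound fraction stays open. Nothing shown offers an explanation for the value of compound 4.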